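The compounds below may be only part of what the source reports. "The series", "measured", "known", "first", "only" and "open" are said of these compounds alone.

Compound 1 (`COc1cc(/C=C/C(=O)/C(=C/c2ccc3ccccc3n2)C(=O)/C=C/C2=C(C)CCCC2(C)C)ccc1O`): 5100 nM
Compound 2 (`COc1cc(/C=C/C(O)=C/C(=O)/C=C/C2=C(C)CCCC2(C)C)cc(OC)c1O`): 12200 nM

In a functional assay on CWR22R cells (Homo sapiens) for cytotoxicity, read by MTT assay, with a stated time of 72 h (a higher number here means a weaker inhibitor, a lower number a stronger inhibitor), compound 1 has the lower of the two numbers, and compound 2 sits higher by more than the usual scatter. Compound 3 (`COc1cc(/C=C(\C(=O)/C=C/C2=C(C)CCCC2(C)C)C(=O)/C=C/c2ccc(O)c(OC)c2)ccc1O`) is still unmeasured. It changes one group of compound 1 (4-hydroxy-3-methoxyphenyl in place of quinolin-2-yl on a double-bonded chain carbon bound to a double-bonded chain carbon), with 4-hydroxy-3-methoxyphenyl in place of quinolin-2-yl on a double-bonded chain carbon bound to a double-bonded chain carbon. For the measured compounds named here, no measured pair shows this change, so the estimate is a loose one. In this assay a small move toward a higher number, within the scatter, is expected (a 1.4-fold higher number from compound 1 to compound 3 (0.14 log units; within the scatter)). Compound 3 is estimated at 7000 nM (expected range 2500 nM to 20000 nM).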

Compound 3, half-maximal inhibitory concentration: 2200 nM
For compound 3 the middle estimate is 3.2-fold (0.50 log units) above the measured one; the whole stated range lies above it.
By their numbers in this assay, from the lowest: compound 3; then compound 1; then compound 2.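

In this assay, the position on a double-bonded chain carbon bound to a double-bonded chain carbon proves sensitive to the group it carries: 4-hydroxy-3-methoxyphenyl in place of quinolin-2-yl gives a 2.3-fold lower number from compound 1 to compound 3 (0.37 log units; beyond the scatter). This modest step is beyond the scatter, so quinolin-2-yl is not required here for the cytotoxicity seen with compound 1. No available measurement explains the step.

A single step cannot show whether the hydroxy or the methoxy matters more. A plain phenyl or a 4-aminophenyl group at this place would help to separate their contributions.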